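The compounds below may be only part of what the source reports. "The series", "measured", "known", "first", "only" and "open" are said of these compounds alone.

Working notes on the series. Compound 1 `Cc1nc(C)c(C(=O)Oc2ccc(/C=C/C(=O)O)cc2)nc1C` and compound 2 `Cc1nc(C)c(C(=O)Oc2cccc(/C=C/C(=O)O)c2)nc1C` share the same atoms, joined differently; the difference between the two cores is not broken down here. In a functional assay on EA.hy 926 cells (Homo sapiens) for cytotoxicity, read by MTT assay, with stated times of 24 h and 12 h, tested at 25 uM (on this read-out lower numbers stand for a weaker effect and higher numbers for a stronger effect at the one concentration tested), compound 1 gives 46.6%, and compound 2 gives 64.3%. Compound 3 `CCOC(=O)/C=C/c1ccc(OC(=O)c2nc(C)c(C)nc2C)cc1` carries the change ethyl in place of hydrogen on an oxygen next to a carbonyl group on the core of compound 1; in this assay compound 3 gives 58.8%, a step of a number 12.2 percentage points higher from compound 1 to compound 3 (beyond the scatter). The same change, (ethyl in place of hydrogen on an oxygen next to a carbonyl group), made on the core of compound 2 gives compound 4 `CCOC(=O)/C=C/c1cccc(OC(=O)c2nc(C)c(C)nc2C)c1`, not yet measured in this assay. A step of similar direction is expected, estimated at about a number 7.7 percentage points higher from compound 2 to compound 4 (within the scatter) because the step of a number 12.2 percentage points higher from compound 1 to compound 3 (beyond the scatter) lies beyond the scatter. Compound 4 is therefore estimated at 72% in this assay, between 60% and 84%.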

Compound 4, a percentage reported as activity, at one concentration (the size of the read-out at that concentration, not a potency): 34.2%
For compound 4 the middle estimate is 37.8 percentage points above the measured one; measured number below the stated range.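

In this assay, ethyl in place of hydrogen on an oxygen next to a carbonyl group gives a number 30.1 percentage points lower from compound 2 to compound 4 (beyond the scatter), so the step seen on the core of compound 1 does not carry over to the core of compound 2 in direction or size: the same change on two cores in this assay, a number 12.2 percentage points higher (beyond the scatter) from compound 1 to compound 3 and a number 30.1 percentage points lower (beyond the scatter) from compound 2 to compound 4, 42.3 percentage points apart, beyond the scatter of two such steps

For these two pairs, the outcome of the carboxy to ethoxycarbonyl change therefore depends on the core that carries it. The two pairs do not show why the direction reverses, nor which of the two steps would be the more usual on a further core.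

The compounds shown leave open how a methyl ester, a longer chain on the ester oxygen or an amide would behave on each core. For the compounds shown here, with only two cores, any rule for choosing between them also stays open.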